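The compounds below may be only part of what the source reports. "The series", "measured", "known", "first", "only" and "open" are said of these compounds alone.

Three compounds have been measured in a functional assay on A549 cells (Homo sapiens) for antiproliferative activity, read by sulforhodamine B assay, with a stated time of 48 h; on this read-out lower numbers stand for stronger inhibition and higher numbers for weaker inhibition:

compound 1 `COc1ccc(/C=C/C(=O)c2ccccc2-c2cccc(F)c2)cc1`: 280 nM
compound 2 `COc1ccc(/C=C/C(=O)c2ccccc2-c2cccc(F)c2)cc1OC`: 330 nM
compound 3 `O=C(/C=C/c1ccccc1-c1ccc(F)cc1)c1cccc(O)c1`: 6900 nM

Compound 2 differs from compound 1 by methoxy in place of hydrogen on an aromatic carbon, and this change gave a 1.2-fold higher number from compound 1 to compound 2 (0.07 log units; within the scatter). Compound 3 rests on a different core from compound 1, and the difference between the two cores is not broken down here. Compound 3 gives the highest number of the three; its nearest neighbour is compound 2.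

Compound 4 `COc1ccc(C(=O)/C=C/c2ccccc2-c2ccc(F)cc2)cc1O` has not yet been measured in this assay. Among the compounds with values here, it differs from compound 3 by methoxy in place of hydrogen on an aromatic carbon, the same kind of change as the one from compound 1 to compound 2, although the surroundings are not the same: in compound 2 the entering methoxy is ortho to a methoxy group and meta to a large group, whereas in compound 4 it is ortho to a hydroxy group and para to a large group. Within the data shown here, the only measured example of this kind of change stayed flat, as a 1.2-fold higher number from compound 1 to compound 2 (0.07 log units; within the scatter) shows, but that result was obtained on the core of compound 1, and the core of compound 3 offers a different setting. The step to compound 4 is therefore expected to be a 2.3-fold lower number from compound 3 to compound 4 (0.36 log units; beyond the scatter), a modest move resting on the flat precedent a 1.2-fold higher number from compound 1 to compound 2 (0.07 log units; within the scatter) with wide room for the different surroundings. Compound 4 is expected to give about 3000 nM, most plausibly between 600 nM and 9000 nM.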

Compound 4, half-maximal inhibitory concentration: 940 nM
Compound 4: middle estimate off by 3.2-fold (0.50 log units), on the high side; the range from low to high includes it.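

In this assay, methoxy in place of hydrogen on an aromatic carbon gave a 7.3-fold lower number from compound 3 to compound 4 (0.87 log units; beyond the scatter), so a change that stayed flat on the core of compound 1 produced a clear move on the second core. The two results lie further apart than the scatter of two such steps, so the outcome of this change did not carry over from one core to the other: the same change on two cores in this assay, a 1.2-fold higher number (0.07 log units; within the scatter) from compound 1 to compound 2 and a 7.3-fold lower number (0.87 log units; beyond the scatter) from compound 3 to compound 4, 8.7-fold (0.94 log units) apart, beyond the scatter of two such steps. This shows that the step depends on its setting, but not whether the core itself or the immediate surroundings of the entering methoxy matter more, and two pairs of compounds give no rule for any further core.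

The compounds shown leave open whether an ethoxy group or an amine entering at the same place would follow the methoxy on each core. They also leave open how the step would run with a carboxylic acid in place of the hydroxy group of compound 4.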